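Swapping fluoro for chloro on a thiourea-linked pyrazole series

This account rests on a few compounds, and the source may have more. Where it says the series, first, only, none or still open, it means among the compounds named here.

Of the compounds shown here, three sharing one core have been tested in a functional assay on NCI-H460 cells (Homo sapiens) for inhibition, read by CCK-8 assay, with a stated time of 48 h; a lower number here means a stronger inhibitor, a higher number a weaker inhibitor. Compound 1 `Cc1ccc(NC(=S)NC(=O)c2cn(-c3ccccc3)nc2-c2ccc(F)cc2)cc1` gives 2980 nM. Compound 2 `Cc1ccc(NC(=S)NC(=O)c2cn(-c3ccccc3)nc2-c2ccc(Cl)cc2)cc1` differs from it by chloro in place of fluoro on an aromatic carbon, and in this assay compound 2 gives 3120 nM; the step is a 1.0-fold higher number from compound 1 to compound 2 (0.02 log units; within the scatter). Compound 3 `O=C(NC(=S)Nc1ccc(F)cc1)c1cn(-c2ccccc2)nc1-c1ccc(F)cc1` differs from compound 1 by fluoro in place of methyl on an aromatic carbon, and in this assay compound 3 gives 3240 nM, a step of a 1.1-fold higher number from compound 1 to compound 3 (0.04 log units; within the scatter). All three numbers sit close together, and none of the gaps between them is large enough to speak of one compound as more or less potent than another.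

The next compound, compound 4 `O=C(NC(=S)Nc1ccc(F)cc1)c1cn(-c2ccccc2)nc1-c1ccc(Cl)cc1`, has not yet been measured. It differs from compound 3 by chloro in place of fluoro on an aromatic carbon. This is the same change already made from compound 1 to compound 2, and its place, on an aromatic carbon of a six-membered aromatic ring of carbon only, para to a large group, is described in the same words in both cases, so it counts as the same change on a core that differs only as told above. On that basis the step in this assay is expected to be a 1.0-fold higher number from compound 3 to compound 4 (0.01 log units; within the scatter), since the earlier run of the change gave a 1.0-fold higher number from compound 1 to compound 2 (0.02 log units; within the scatter). Compound 4 is therefore estimated to give 3300 nM, with a range expected from 1700 nM to 6500 nM.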

Compound 4, half-maximal inhibitory concentration: 3640 nM
The estimate for compound 4 lay 1.1-fold (0.04 log units) below the measured number; the measured number falls inside the stated range.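

In this assay, the change from 4-fluorophenyl to 4-chlorophenyl gives a 1.1-fold higher number from compound 3 to compound 4 (0.05 log units; within the scatter), and it reads the same on both cores: the same change on two cores in this assay, a 1.0-fold higher number (0.02 log units; within the scatter) from compound 1 to compound 2 and a 1.1-fold higher number (0.05 log units; within the scatter) from compound 3 to compound 4, 1.1-fold (0.03 log units) apart, within the scatter of two such steps. The other change, fluoro in place of methyl on an aromatic carbon, now also has a second run, a 1.2-fold higher number from compound 2 to compound 4 (0.07 log units; within the scatter), and it too matches its first: the same change on two cores in this assay, a 1.1-fold higher number (0.04 log units; within the scatter) from compound 1 to compound 3 and a 1.2-fold higher number (0.07 log units; within the scatter) from compound 2 to compound 4, 1.1-fold (0.03 log units) apart, within the scatter of two such steps. So each change carried from one core to another here, but only in the sense that every step stayed within the scatter; this shows that these two swaps make no measurable difference on these cores, not that a change with a large step would carry over as faithfully, and two runs of each change are too few to support a general rule.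

The compounds shown carry only fluoro, chloro and methyl on those aromatic carbons, so it remains open whether a methoxy group, a nitrile, an amine or a carboxylic acid there would give a step beyond the scatter, and whether such a step would repeat from one core to the other. The thiourea link is also the same in all four compounds, which leaves open what a urea or a plain amide in its place would give.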